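Pyridin-4-yl to 4-hydroxyphenyl in compound 1

The compounds below may be only part of what the source reports. "The series", "measured", "known", "first", "only" and "open" are said of these compounds alone.

Within the data shown here, in a functional assay on RKO cells (Homo sapiens) for inhibition, read by CCK-8 assay, with a stated time of 4 days (on this read-out higher numbers stand for weaker inhibition and lower numbers for stronger inhibition), compound 1 `COc1cc(C(=O)O)ccc1NC(=O)[C@@H]1N[C@@H](CC(C)(C)C)[C@](CNCc2ccncc2)(c2ccc(Cl)cc2F)[C@H]1c1cccc(Cl)c1F` gives 200 nM, the lower of the two numbers measured so far. Compound 2 `COc1cc(C(=O)O)ccc1NC(=O)[C@@H]1N[C@@H](CC(C)(C)C)[C@](CNCc2ccncc2)(c2ccc(Cl)cc2F)[C@H]1c1cccc(Cl)c1Cl` gives 440 nM. Among the measured compounds shown here, the single measured step, chloro in place of fluoro on an aromatic carbon, is modest and beyond the scatter: a 2.2-fold higher number from compound 1 to compound 2 (0.34 log units; beyond the scatter).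

Compound 3 `COc1cc(C(=O)O)ccc1NC(=O)[C@@H]1N[C@@H](CC(C)(C)C)[C@](CNCc2ccc(O)cc2)(c2ccc(Cl)cc2F)[C@H]1c1cccc(Cl)c1F` keeps the core of compound 1 but has 4-hydroxyphenyl in place of pyridin-4-yl on a saturated chain carbon bound to an amine nitrogen. For the measured compounds named here, no measurement yet covers a change at this place, so the chloro step serves only as a guide to size and says little about direction. A modest move toward a higher number in this assay is tentatively expected, and a move the other way is not excluded. The estimated change is a 1.5-fold higher number from compound 1 to compound 3 (0.18 log units; within the scatter). For compound 3, the expected value is 300 nM, with an estimated range of 100 nM to 900 nM.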

Compound 3, half-maximal inhibitory concentration: 600 nM
Beside the measured number, compound 3's estimate is 2.0-fold (0.30 log units) below it, within the range that was stated.
By their numbers in this assay, from the lowest: compound 1; then compounds 2 and 3 (each within the scatter of the next).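

In this assay, among these compounds, this is the first reading at the position on a saturated chain carbon bound to an amine nitrogen: 4-hydroxyphenyl in place of pyridin-4-yl gives a 3.0-fold higher number from compound 1 to compound 3 (0.48 log units; beyond the scatter) and so gives up some of the inhibition seen with compound 1. The position therefore responds to the identity of this aromatic ring, and the step is larger than the scatter. The change swaps a ring with one hetero atom for an all-carbon ring bearing a hydroxyl, and no measured evidence accounts for the step.

This single pair cannot separate loss of the ring nitrogen from gain of the hydroxyl, and an unsubstituted phenyl ring or a pyridin-3-yl ring would bear on that question. Also open, as far as these compounds go, is whether a longer chain between the amine and the ring would be tolerated.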